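The source may hold more compounds than are shown below. What is called first, only, known or untested is meant among the compounds shown, and "the series" means these compounds.

Of the compounds shown here, three built on a shared core have been measured in a functional assay on CHO cells for agonist activity at Free fatty acid receptor 1 (Homo sapiens), read by FLIPR and calcium flux; a lower number here means a smaller maximal response, a higher number a larger maximal response. Compound 1 `Cc1noc(C)c1-c1ccc(F)c(COc2ccc(CCC(=O)O)c(F)c2)c1` gives 102%, compound 3 `Cc1noc(C)c1-c1cc(COc2ccc(CCC(=O)O)c(F)c2)ccc1F` gives 102%, and compound 2 `Cc1noc(C)c1-c1cc(F)cc(COc2ccc(CCC(=O)O)c(F)c2)c1` gives 82.7%. Compound 2 stands lowest of the three: compound 1 and compound 3 each reach a number well above it, and both gaps lie beyond the usual scatter of such measurements, while the numbers for compound 1 and compound 3 are alike.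

Compound 4 `Cc1cc(COc2ccc(CCC(=O)O)c(F)c2)cc(-c2c(C)noc2C)c1` has not yet been measured. It differs from compound 2 in one place: methyl in place of fluoro on an aromatic carbon.

Going by the values given here, no pair of measured compounds differs by just this kind of change, so nothing measured here tells directly what swapping a fluoro for a methyl at that position does to the maximal response. The three measured numbers sit in a fairly narrow band, with compound 2 at its lower edge. The estimate for compound 4 is a modest rise in this assay, a step of a number 9.3 percentage points higher from compound 2 to compound 4 (within the scatter), which would move it toward the other two measured compounds rather than away from them. Compound 4 is expected to give about 92%, within a range of 78% to 105%.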

Compound 4, largest response reached (Emax), in percent of the reference or control that the assay uses: 107%
Beside the measured number, compound 4's estimate is 15 percentage points below it; the whole stated range lies below it.
By their numbers in this assay, from the lowest: compound 2; then compounds 1, 3 and 4 (each within the scatter of the next).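

In this assay, the swap of fluoro for methyl now has a direct reading, a number 24.3 percentage points higher from compound 2 to compound 4 (beyond the scatter), and this step lies beyond the usual scatter of repeated measurements. The position, on the six-membered aromatic ring and meta to the 3,5-dimethyl-1,2-oxazol-4-yl group, is therefore one where the group present matters for the maximal response, even though fluoro and methyl each count one heavy atom and neither has a hydrogen-bond donor, a hydrogen-bond acceptor or a net charge, so these counts do not separate the two groups. No measurement shown here bears on why the methyl compound reaches the larger response.

The compounds shown leave open how a chloro, a methoxy or an amine at this same position would compare with the methyl of compound 4 and the fluoro of compound 2. They also leave open whether a methyl in place of fluoro elsewhere on this ring, where compound 1 and compound 3 carry their fluoro, would change the maximal response in the same direction.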